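The source may hold more compounds than are shown below. What is called first, only, known or untested is meant among the compounds shown, and "the series" means these compounds.

compound 1 `O=C(N/N=C/c1ccco1)c1cccc(S(=O)(=O)N2CCOCC2)c1`: > 100000 nM in a functional assay on MCF7 cells (Homo sapiens) for antiproliferative activity, read by MTT assay, with a stated time of 72 h (a lower number here means a stronger inhibitor, a higher number a weaker inhibitor), a limit.
compound 2 `O=C(N/N=C/c1ccccc1O)c1cccc(S(=O)(=O)N2CCOCC2)c1`: 29100 nM in this assay.

Compound 2 holds the only number shown; the other value is a limit. Within the data shown here, the step of an at least 3.4-fold lower number from compound 1 to compound 2 (0.53 log units; beyond the scatter) is the sole measured step, and its start lies at the limit of > 100000 nM in this assay, at which 1 of the 2 values shown sits. Compound 3 `CCN(CC)c1ccc(/C=N/NC(=O)c2cccc(S(=O)(=O)N3CCOCC3)c2)c(O)c1` differs from compound 2 by diethylamino in place of hydrogen on an aromatic carbon. Among the measured compounds shown here, no measured step adds a group of this kind to the ring carrying the hydroxy group, so the step from compound 1 gives only indirect guidance; a change of modest size at most is expected, in either direction, or none beyond the scatter. For compound 3 the estimate is 20000 nM (range 6000 nM to 60000 nM). The step implied, a 1.5-fold lower number from compound 2 to compound 3 (0.16 log units; within the scatter), is the expected size.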

Compound 3, half-maximal inhibitory concentration: 3520 nM
Compound 3: middle estimate off by 5.7-fold (0.75 log units), on the high side; the measured number lies below the stated range.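

In this assay, diethylamino in place of hydrogen on the aromatic carbon meta to a hydroxy group and para to a large group gives an 8.3-fold lower number from compound 2 to compound 3 (0.92 log units; beyond the scatter), so this position accepts a substituent of 5 heavy atoms and the number falls beyond the scatter. This is the first step in the series with a number at both ends, as compound 1 stands at a limit: the limit of > 100000 nM in this assay, at which 1 of the 3 values shown sits.

Open, as far as these compounds go, is whether the nitrogen or the ethyl chains carry the step; a methoxy, dimethylamino or pyrrolidine group at this carbon would separate them. Also open, from the compounds shown here alone, is whether the step depends on the hydroxy group.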